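Hydroxy-dimethylphenyl analogue of a chromone-derived antiproliferative series

The source may hold more compounds than are shown below. What is called first, only, known or untested is meant among the compounds shown, and "the series" means these compounds.

Measured compounds:
compound 1 `CCC1=C(O)c2c(oc(-c3cccc(OC)c3)cc2=O)C(CC)(CC)C1=O`, a functional assay on KB cells (Homo sapiens) for antiproliferative activity, read by sulforhodamine B assay, with a stated time of 3 days; a lower number here means that less compound is needed, a higher number that more compound is needed for the effect: 13.3 uM
compound 2 `CCC1=C(O)c2c(oc(-c3ccc(OC)c(OC)c3)cc2=O)C(CC)(CC)C1=O`, this assay: 14.7 uM
compound 3 `CCC1=C(O)c2c(oc(-c3cc(C)c(OC)cc3C)cc2=O)C(CC)(CC)C1=O`, this assay: 36.6 uM

Compound 1 holds the lowest number of the three in this assay. Compound 2 sits closest, with a 1.1-fold higher number from compound 1 to compound 2 (0.04 log units; within the scatter); compound 3 lies furthest, and the two values show a gap beyond the scatter, in the direction of a higher number for compound 3.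

Compound 4 `CCC1=C(O)c2c(oc(-c3ccc(O)c(C)c3C)cc2=O)C(CC)(CC)C1=O` has not been measured. It differs from compound 1 in one place: 4-hydroxy-2,3-dimethylphenyl in place of 3-methoxyphenyl on an aromatic carbon. Among the compounds with values here, no measured step matches this change. Within the data shown here, the only single step in hand, a 1.1-fold higher number from compound 1 to compound 2 (0.04 log units; within the scatter), is within the scatter, while the two values of compound 1 and compound 3 show that a dimethylated ring with a methoxy group carries a higher number. On that basis a modest move toward a higher number is expected, a 1.8-fold higher number from compound 1 to compound 4 (0.26 log units; within the scatter), with wide uncertainty. Compound 4 is therefore estimated at 24 uM in this assay, likely between 9 uM and 65 uM.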

Compound 4, concentration for half-maximal effect: 6.5 uM
The estimate for compound 4 lay 3.7-fold (0.57 log units) above the measured number, outside the stated range (below it).
By their numbers in this assay, from the lowest: compound 4; then compounds 1 and 2 (each within the scatter of the next); then compound 3.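

At the aromatic carbon next to the ring oxygen, 4-hydroxy-2,3-dimethylphenyl in place of 3-methoxyphenyl gives a 2.0-fold lower number from compound 1 to compound 4 (0.31 log units; beyond the scatter) in this assay. This is the only step shown at this position that lies beyond the scatter, whereas the step adding a methoxy group, a 1.1-fold higher number from compound 1 to compound 2 (0.04 log units; within the scatter), stays within it. The entering group carries a hydrogen-bond donor that the leaving group lacks, but no evidence here accounts for the lower number.

The compounds shown do not separate the contribution of the hydroxy group from that of the two methyl groups, since all three enter together in compound 4. As far as these compounds go, whether an amine or a carboxylic acid in place of that hydroxy group would keep the number as low also remains open.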